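This account rests on a few compounds, and the source may have more. Where it says the series, first, only, none or still open, it means among the compounds named here.

Measured so far:
compound 1 `O=C1NC(=O)C(c2ccccc2)CC1c1ccccc1` — 11 mg/kg
compound 2 `O=C1C(c2ccccc2)CC(c2ccccc2)C(=O)N1c1cccc(Cl)c1` — > 100 mg/kg
compound 3 `O=C1C(c2ccccc2Cl)CC(c2ccccc2Cl)C(=O)N1c1ccccc1` — 61.4 mg/kg

In a functional assay on the whole organism (strain Swiss albino) with Mus musculus as the target, in the maximal electroshock model, with a stated time of 2 h (on this read-out higher numbers stand for an effect only at larger amounts of compound and lower numbers for an effect already at smaller amounts), compound 1 gives 11 mg/kg. For compound 2 the value of > 100 mg/kg is a limit of this assay, not a number. Compound 3 gives 61.4 mg/kg and so stands highest of the two numbers; the nearest number is that of compound 1, which lies lower by more than the usual scatter.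

Compound 4 `Cc1ccc(N2C(=O)C(c3ccccc3Cl)CC(c3ccccc3Cl)C2=O)cc1` differs from compound 3 by methyl in place of hydrogen on an aromatic carbon, para to a large group; cut one bond further out, the change reads phenyl to 4-methylphenyl. Within the data shown here, the only measured step, an at least 9.0-fold higher number from compound 1 to compound 2 (0.95 log units; beyond the scatter), concerns a 3-chlorophenyl in place of hydrogen on the amide-type nitrogen in the ring, a change at a different place, and it ended at a limit, as noted in the limit of > 100 mg/kg in this assay, at which 1 of the 3 values shown sits. Among the measured compounds shown here, no measured step touches a methyl on the aryl group carried by that nitrogen. The expectation for compound 4 is therefore a step of a 1.0-fold lower number from compound 3 to compound 4 (0.01 log units; within the scatter), that is, none beyond the scatter. Compound 4 is estimated at 60 mg/kg, with a range from 25 mg/kg to 150 mg/kg.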

Compound 4, dose for half-maximal effect: 41.2 mg/kg
For compound 4 the middle estimate is 1.5-fold (0.16 log units) above the measured one, and the stated range covers the measured number.
By their numbers in this assay, from the lowest: compound 1; then compounds 4 and 3 (each within the scatter of the next). At a limit, above all of these: compound 2.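

Methyl in place of hydrogen on an aromatic carbon, para to a large group, gives a 1.5-fold lower number from compound 3 to compound 4 (0.17 log units; within the scatter) in this assay and so leaves the read-out unchanged beyond the scatter; phenyl to 4-methylphenyl is therefore a tolerated change on this background. Among these compounds, the earlier compounds could not show this: the only earlier step, an at least 9.0-fold higher number from compound 1 to compound 2 (0.95 log units; beyond the scatter), places a 3-chlorophenyl group on the amide-type nitrogen itself, not a methyl on an aryl group already there, and it ends at a limit for compound 2, not at a number. The information at hand offers nothing that accounts for the size of the new step.

Going by these compounds, whether a larger or differently built group at the same ring carbon, such as an amine, a carboxylic acid or a longer chain in place of methyl, also stays within the scatter of compound 3 remains open. Also open, on these data alone, is whether phenyl to 4-methylphenyl reads the same on a core without the two chlorines that compound 3 and compound 4 share.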